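The source may hold more compounds than are shown below. What is called first, only, known or untested is meant among the compounds shown, and "the series" means these compounds.

Measured compounds:
Compound 1 `C=CC(=O)Nc1cccc(NC(=O)CSc2nc(Nc3ccccc3C)c3ccccc3n2)c1` gives 30200 nM in a functional assay on MGC-803 cells (Homo sapiens) for inhibition, read by MTT assay, with a stated time of 72 h; on this read-out lower numbers stand for stronger inhibition and higher numbers for weaker inhibition.
Compound 2 `C=CC(=O)Nc1cccc(NC(=O)CSc2nc(Nc3cccc(F)c3)c3ccccc3n2)c1` gives 6250 nM in this assay.

Going by the values given here, compound 2 stands at the lower of the two numbers; the single measured step, a 4.8-fold lower number from compound 1 to compound 2 (0.68 log units; beyond the scatter), is the whole spread of the set so far.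

Compound 3 `C=CC(=O)Nc1cccc(NC(=O)CSc2nc(Nc3cccc(Cl)c3)c3ccccc3n2)c1` differs from compound 2 by chloro in place of fluoro on an aromatic carbon of a six-membered aromatic ring of carbon only, meta to a large group. Among the compounds with values here, the one measured step changes both the group and its place at once, so it does not speak to a halogen exchange at a fixed place; no measured step bears directly on this change. The expected step is therefore none beyond the scatter, a 1.3-fold lower number from compound 2 to compound 3 (0.10 log units; within the scatter). Compound 3 is estimated at 5000 nM in this assay, with a range from 1500 nM to 15000 nM.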

Compound 3, half-maximal inhibitory concentration: 7830 nM
Beside the measured number, compound 3's estimate is 1.6-fold (0.19 log units) below it; measured number inside the range.
By their numbers in this assay, from the lowest: compounds 2 and 3 (each within the scatter of the next); then compound 1.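

In this assay, going by these compounds alone, chloro in place of fluoro on this aromatic carbon, meta to a large group, gives a 1.3-fold higher number from compound 2 to compound 3 (0.10 log units; within the scatter), the first reading of a halogen exchange at a fixed place, and it does not separate the two compounds. The step of a 3.9-fold lower number from compound 1 to compound 3 (0.59 log units; beyond the scatter) places the 3-chlorophenyl compound on the same side of compound 1 as the 3-fluorophenyl compound, although this step, too, changes group and place at once. Nothing measured bears on why the two halogens read alike.

Still open, on these data alone, is whether the gap from compound 1 follows the group or its place, which 3-methylphenyl or 2-fluorophenyl on the same nitrogen would separate. Also open, as far as these compounds go, is how a methoxy, a nitrile or an amine would read at this aromatic carbon.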